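A few compounds are considered here, and "the series" means these few. Any claim that something is new, unique, unknown or untested is made for them only; others in the source may bear on it.

Measured so far in a functional assay on MDA-MB-231 cells (Homo sapiens) for cytotoxicity, read by MTT assay, with a stated time of 72 h; a lower number here means a stronger inhibitor, a higher number a weaker inhibitor:
compound 1 `COc1cc2c(Oc3ccc(NC(=O)c4nn(-c5ccc(Br)cc5)c(=O)c5ccccc45)cc3F)ccnc2cc1OCCCN1CCCC1` gives 1160 nM;
compound 2 `COc1cc2c(Oc3ccc(NC(=O)c4nn(-c5ccc(F)cc5)c(=O)c5ccccc45)cc3F)ccnc2cc1OCCCN1CCN(C)CC1` gives 460 nM;
compound 3 `COc1cc2c(Oc3ccc(NC(=O)c4nn(-c5ccccc5F)c(=O)c5ccccc45)cc3F)ccnc2cc1OCCCN1CCN(C)CC1` gives 1050 nM.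

Compound 3 stands second highest of the three numbers in this assay. Its nearest neighbour is compound 1, whose number is within the scatter of it; compound 2 is furthest, with a lower number beyond the scatter. Among the compounds with values here, the only single-point step among the measured compounds is a 2.3-fold higher number from compound 2 to compound 3 (0.36 log units; beyond the scatter), which shows that a 4-fluorophenyl group on the aromatic nitrogen gives a lower number than a 2-fluorophenyl one on this core.

Compound 4 `COc1cc2c(Oc3ccc(NC(=O)c4nn(-c5ccc(Br)cc5)c(=O)c5ccccc45)cc3F)ccnc2cc1OCCCN1CCN(C)CC1` differs from compound 3 by one change: 4-bromophenyl in place of 2-fluorophenyl on an aromatic nitrogen. Within the data shown here, this reverses the direction of the step from compound 2 to compound 3, but also exchanges fluorine for bromine, and no measured pair isolates that second element. Compound 1, which carries the same 4-bromophenyl group but a pyrrolidine tail instead of the methylpiperazine one, gives a number near that of compound 3, so the two reference points pull in different directions.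

The expectation for compound 4 is therefore a modest downward step, a 1.5-fold lower number from compound 3 to compound 4 (0.18 log units; within the scatter), with a number in this assay estimated at 700 nM (range 350 nM to 1500 nM).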

Compound 4, half-maximal inhibitory concentration: 1370 nM
Estimate against measurement, compound 4: 2.0-fold (0.29 log units) below; low and high end bracket the measured number.
By their numbers in this assay, from the lowest: compound 2; then compounds 3, 1 and 4 (each within the scatter of the next).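

In this assay, bromo in place of fluoro on the phenyl group on the aromatic nitrogen, with the 4-methylpiperazin-1-yl tail held constant, is a step beyond the scatter (a 3.0-fold higher number from compound 2 to compound 4 (0.47 log units; beyond the scatter)), so at this position the 4-fluorophenyl group of compound 2 is separated from the 4-bromophenyl group of compound 4. The same position shows no such separation between 4-bromophenyl and 2-fluorophenyl (a 1.3-fold higher number from compound 3 to compound 4 (0.12 log units; within the scatter)), as that step lies within the scatter, and of the three groups on this tail only the 4-fluorophenyl one stands apart. The tail change is also within the scatter when the 4-bromophenyl group is present (a 1.2-fold higher number from compound 1 to compound 4 (0.07 log units; within the scatter)), so 4-methylpiperazin-1-yl and pyrrolidin-1-yl cannot be told apart on this background.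

As far as these compounds go, it remains open whether the tail is equally indifferent with the 4-fluorophenyl group in place, and where an unsubstituted phenyl, a 4-chlorophenyl or a 4-methoxyphenyl group would fall at this position. Nothing available gives a reason for any of these steps.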